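Dropping the ring methyl: expected solubility of compound 3

The source may hold more compounds than are shown below. What is called first, only, known or untested is meant among the compounds shown, and "the series" means these compounds.

Within the data shown here, compound 1 `CCOC(=O)c1c(-c2cccc([N+](=O)[O-])c2)[nH]c2cccc(OC)c2c1=O` and compound 2 `CCOC(=O)c1c(-c2ccccc2C)[nH]c2cc(OC)ccc2c1=O` are the two measured members, and they differ in more than one place, so no single step links them. In a physicochemical assay for solubility, in phosphate buffer, at pH 7.4 (on this read-out higher numbers stand for higher solubility and lower numbers for lower solubility), compound 1 gives 49000 nM. For compound 2 the this assay reports only a limit, > 100000 nM. Compound 2 therefore stands at the top of the numbers shown (the limit of > 100000 nM in this assay, at which 1 of the 2 values shown sits). Compound 3 `CCOC(=O)c1c(-c2ccccc2)[nH]c2cc(OC)ccc2c1=O` is not yet measured; it differs from compound 2 by hydrogen in place of methyl on an aromatic carbon. Among the measured compounds shown here, no measured step of this kind exists, so the size of the step cannot be read from the data; the expectation is no change beyond the usual scatter, with any drift more likely toward higher solubility than lower. The estimated step is a step that the limit leaves unreadable from compound 2 to compound 3. Compound 3 is expected to give about 130000 nM, with a range from 60000 nM to 300000 nM, most likely again returned as a limit rather than a number.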

Compound 3, solubility: > 100000 nM
Compound 3: a limit, no number; the forecaster's own chance of this, stated with the estimate: 65%; the middle value is on the limit's open side.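

Compound 2 and compound 3 both return only a limit in this assay, so no step between them can be read: the limit of > 100000 nM in this assay, at which 2 of the 3 values shown sit.

The compounds shown leave open whether hydrogen in place of methyl on an aromatic carbon changes solubility at all.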